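A few compounds are considered here, and "the series" means these few. Any claim that something is new, unique, unknown or untested is made for them only; others in the source may bear on it.

Of the compounds shown here, three built on one shared core have been measured in a functional assay on MDA-MB-435 cells (Homo sapiens) for inhibition, read by sulforhodamine B assay, with a stated time of 48 h; a lower number here means a stronger inhibitor of growth, a higher number a weaker inhibitor of growth. Compound 1 `O=C(Nc1cccc(-n2cc(-c3ccncc3)c(-c3ccc(Cl)c(O)c3)n2)c1)Nc1cccc(C(F)(F)F)c1` gives 1490 nM. Compound 2 `COc1cc(-c2nn(-c3cccc(NC(=O)c4cccc(C(F)(F)F)c4)c3)cc2-c2ccncc2)ccc1Cl` gives 705 nM, and compound 3 `COc1cc(-c2nn(-c3cccc(NC(=O)Nc4ccc(Cl)c(Cl)c4)c3)cc2-c2ccncc2)ccc1Cl` gives 938 nM; compound 3 stands second highest of the three, though both gaps lie within the scatter. Going by the values given here, the single one-place step measured, a 1.3-fold higher number from compound 2 to compound 3 (0.12 log units; within the scatter), shows how little a swap at the carbonyl carbon moved the result. Compound 4 `COc1cc(-c2nn(-c3cccc(NC(=O)Nc4cccc(C(F)(F)F)c4)c3)cc2-c2ccncc2)ccc1Cl` differs from compound 3 by 3-(trifluoromethyl)phenyl in place of 3,4-dichlorophenyl on an amide-type nitrogen. Among the compounds with values here, no measured step bears directly on this change; the one step seen was small, and compound 1, which carries the same entering group, gave 1490 nM. The expected step is therefore a 1.1-fold lower number from compound 3 to compound 4 (0.04 log units; within the scatter), none beyond the scatter. Compound 4 is estimated at 850 nM, within 400 nM to 1800 nM.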

Compound 4, concentration for 50% growth inhibition: 866 nM
For compound 4 the middle estimate is 1.0-fold (0.01 log units) below the measured one; low and high end bracket the measured number.
By their numbers in this assay, from the lowest: compounds 2, 4, 3 and 1 (each within the scatter of the next, the first and the last beyond it).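

On the amide-type nitrogen, this assay does not separate 3-(trifluoromethyl)phenyl from 3,4-dichlorophenyl: the swap gives a 1.1-fold lower number from compound 3 to compound 4 (0.03 log units; within the scatter). Two further single changes also stay within the scatter: (3-(trifluoromethyl)phenyl)amino in place of 3-(trifluoromethyl)phenyl on the carbonyl carbon gives a 1.2-fold higher number from compound 2 to compound 4 (0.09 log units; within the scatter), and methyl in place of hydrogen on the oxygen gives a 1.7-fold lower number from compound 1 to compound 4 (0.24 log units; within the scatter). Nothing available explains why these steps are so small.

Still open, going by these compounds, is whether a group of another kind on the amide-type nitrogen, such as a carboxylic acid or an amine in place of these substituted phenyl groups, would move the number beyond the scatter.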